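A few compounds are considered here, and "the series" means these few. Any claim that something is new, unique, unknown or untested is made for them only; others in the source may bear on it.

Measured so far in a functional assay on SU-DHL-6 cells (Homo sapiens) for antiproliferative activity, read by MTT assay; a lower number here means a stronger inhibitor, a higher number a weaker inhibitor:
- compound 1 `COc1ncc(-c2ccc3ncnc(N[C@H]4CCCN(C(=O)c5cccnc5)C4)c3c2)cc1C#N`: 120 nM
- compound 2 `COc1ncc(-c2ccc3ncnc(N[C@H]4CCCN(C(=O)C(F)(F)F)C4)c3c2)cc1[N+](=O)[O-]`: 127000 nM

Compound 1 holds the lower of the two numbers, and the gap to compound 2 lies beyond the scatter. Compound 3 `COc1ncc(-c2ccc3ncnc(N[C@H]4CCCN(C(=O)c5coc([N+](=O)[O-])c5)C4)c3c2)cc1C#N` is the next to be read. It keeps the core of compound 1 and changes one group: 5-nitrofuran-3-yl in place of pyridin-3-yl on a carbonyl carbon. Going by the values given here, no single-change step between measured compounds is available as a guide, so the expectation in this assay is only a modest rise in the number, somewhat beyond the scatter. The estimated step is a 2.9-fold higher number from compound 1 to compound 3 (0.46 log units; beyond the scatter). For compound 3 the estimated value is 350 nM, with an expected range of 70 nM to 2500 nM.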

Compound 3, half-maximal inhibitory concentration: 140 nM
Compound 3: the middle estimate sits 2.5-fold (0.40 log units) above what was measured; low and high end bracket the measured number.
By their numbers in this assay, from the lowest: compounds 1 and 3 (each within the scatter of the next); then compound 2.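

In this assay, 5-nitrofuran-3-yl in place of pyridin-3-yl on a carbonyl carbon gives a 1.2-fold higher number from compound 1 to compound 3 (0.07 log units; within the scatter). This position therefore accepts a five-membered aromatic ring bearing a nitro group as well as the six-membered pyridin-3-yl ring, at least for this pair on the core of compound 1. Nothing available bears on why the two groups read alike.

As far as these compounds go, whether the nitro group itself matters remains open. A plain furan-3-yl ring, or an amine or a nitrile in place of the nitro group, would separate the contribution of the ring from that of its substituent.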